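The compounds below may be only part of what the source reports. "The series", "measured", "known", "first", "only" and "open" are said of these compounds alone.

Measured compounds:
Compound 1, `COc1cc(Nc2nc3cccc(-c4ccccc4OC(F)(F)F)c3o2)cc(OC)c1OC`. In an assay on BAF cells for inhibition of ribosomal protein S6 kinase alpha-2 (Mus musculus) (a higher number here means a weaker inhibitor, a lower number a stronger inhibitor), compound 1 gives > 20000 nM, which is a limit of the assay.
Compound 2, `COc1cc(Nc2nc3cccc(-c4ccccc4-c4cn[nH]c4)c3o2)cc(OC)c1OC`. In this assay compound 2 gives > 20000 nM, which is a limit of the assay.

Among the measured compounds shown here, compound 2 thus stands at the limit of this assay, and the only further value shown, that of compound 1, is a limit as well; the step that the two limits leave unreadable from compound 1 to compound 2 cannot be read, since (the limit of > 20000 nM in this assay, at which 2 of the 2 values shown sit).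

Compound 3, `COc1cc(Nc2nc3cccc(-c4cccc5cn[nH]c45)c3o2)cc(OC)c1OC`, differs from compound 2 by a group of 9 heavy atoms (7 carbon, 2 nitrogen; one five-membered aromatic ring with 2 hetero atoms, one six-membered aromatic ring of carbon only) in place of a group of 11 heavy atoms (9 carbon, 2 nitrogen; one five-membered aromatic ring with 2 hetero atoms, one six-membered aromatic ring of carbon only), on an aromatic carbon, on an aromatic carbon of a six-membered aromatic ring of carbon only, part of a fused or bridged system of two rings, ortho to a fused ring and meta to a fused ring. For the measured compounds named here, no measured step speaks to this change in size, and the two values that exist are both limits. The expectation for compound 3 in this assay therefore rests only on where compound 2 stands. Compound 3 is expected to give about 40000 nM, within a range from 8000 nM to 200000 nM. This estimate means a step that the limit leaves unreadable from compound 2 to compound 3, which is expected to stay within the scatter, and most likely the assay will again report only a limit for compound 3.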

Compound 3, half-maximal inhibitory concentration: 5700 nM
Estimate against measurement, compound 3: 7.0-fold (0.85 log units) above; the whole stated range lies above it.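

With 1H-indazol-7-yl on this aromatic carbon, compound 3 is the only one of the three compounds shown to give a number rather than a limit in this assay (5700 nM). Setting a group of 9 heavy atoms in place of a larger group gives an at least 3.5-fold lower number from compound 2 to compound 3 (0.54 log units; beyond the scatter) and 1H-indazol-7-yl in place of 2-(trifluoromethoxy)phenyl gives an at least 3.5-fold lower number from compound 1 to compound 3 (0.54 log units; beyond the scatter), which shows that the outcome at this position depends on the group placed there and that a measurable value can be reached with this one. Both steps start from a limit, so their full size cannot be read: the limit of > 20000 nM in this assay, at which 2 of the 3 values shown sit.

The groups of compound 2 and compound 3 each hold a five-membered aromatic ring with 2 hetero atoms, a six-membered aromatic ring of carbon only, 1 hydrogen-bond donor and 1 hydrogen-bond acceptor, so the compounds shown leave open which difference between the two groups goes with the lower number. They also leave open how an aminomethyl group or a carboxylic acid on this aromatic carbon would compare with 1H-indazol-7-yl.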